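A few compounds are considered here, and "the series" means these few. Any claim that something is new, unique, unknown or untested is made for them only; others in the source may bear on it.

Measured compounds:
Compound 1, `COc1ccc(Br)cc1-c1nc2cc(F)ccc2[nH]1`: 2600 nM
Compound 2, `COc1cc(Br)c(-c2nc3cc(F)ccc3[nH]2)cc1OC`: 1570 nM
Compound 3, `COc1ccc(Br)cc1-c1nc2cc(Cl)ccc2[nH]1`: 2620 nM

All three numbers come from an assay for inhibition of Alpha amylase (Homo sapiens), with a stated time of 10 min; on this read-out lower numbers stand for stronger inhibition and higher numbers for weaker inhibition. Among the measured compounds shown here, compound 1 and compound 3 share one core, and the only change between them is chloro in place of fluoro on an aromatic carbon. The step it made, a 1.0-fold higher number from compound 1 to compound 3 (0.00 log units; within the scatter), is as flat as a step can be. Compound 2 is built on a different core; how the two cores differ is not broken down here, and the three values from compound 1, compound 2 and compound 3 all lie within the usual scatter of one another, so no order among them can be read.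

Compound 4, `COc1cc(Br)c(-c2nc3cc(Cl)ccc3[nH]2)cc1OC`, has not yet been measured in this assay. It carries the change chloro in place of fluoro on an aromatic carbon on the core of compound 2, and since the place is the same word for word as in the pair of compound 1 and compound 3, this is the same change, made a second time. Its expected effect rests on a 1.0-fold higher number from compound 1 to compound 3 (0.00 log units; within the scatter), so for compound 4 the expected step is a 1.0-fold higher number from compound 2 to compound 4 (0.01 log units; within the scatter). The estimate for compound 4 in this assay is therefore 1600 nM, with a likely range from 800 nM to 3200 nM, before the actual number is known.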

Compound 4, half-maximal inhibitory concentration: 1730 nM
Compound 4: the middle estimate sits 1.1-fold (0.03 log units) below what was measured, and the stated range covers the measured number.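

In this assay, chloro in place of fluoro on an aromatic carbon, made on the second core, gives a 1.1-fold higher number from compound 2 to compound 4 (0.04 log units; within the scatter). Set beside the earlier step, the two results agree: the same change on two cores in this assay, a 1.0-fold higher number (0.00 log units; within the scatter) from compound 1 to compound 3 and a 1.1-fold higher number (0.04 log units; within the scatter) from compound 2 to compound 4, 1.1-fold (0.04 log units) apart, within the scatter of two such steps. So on both cores shown the exchange of these two halogens leaves the number where it was, and the flat result carries from one core to the other; what this does not show is that a step of real size would carry in the same way, since neither step rises out of the scatter and only two cores are compared.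

All four compounds carry only fluoro or chloro at this place, so the series shown says nothing about how an amine, a carboxylic acid, a nitrile or a longer chain would read there. It also leaves open whether the bromo and methoxy groups, which all four compounds keep, matter for the numbers in this assay.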